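Swapping a Sulfinylmethyl for an Acetoxymethyl Group

The compounds below may be only part of what the source reports. "The series", "measured", "known", "first", "only" and "open" are said of these compounds alone.

Compound 1, `Cc1nc2c(OCc3ccccc3)cccn2c1C(N)=O`, gives 2% in a functional assay on the whole organism (stomach) for inhibition, with Canis familiaris (Canis lupus familiaris) as the target, at a dose of 5 mg/kg by the intravenous route; a lower number here means a weaker effect, a higher number a stronger effect of the compound at the dose given.
Compound 2, `CCSCc1c(C)nc2c(OCc3ccccc3)cccn12`, gives 0%.
Compound 3, `Cc1nc2c(OCc3ccccc3)cccn2c1C[S+](C)[O-]`, gives 18%.

Compound 3 stands highest of the three measured numbers, and its lead over each of the other two lies beyond the scatter. Compound 4, `CC(=O)OCc1c(C)nc2c(OCc3ccccc3)cccn12`, differs from it by a group of 4 heavy atoms (2 carbon, 2 oxygen; no ring) in place of a group of 3 heavy atoms (1 carbon, 1 oxygen, 1 sulfur; no ring), on a saturated chain carbon bound to an aromatic carbon. Two measured steps end at compound 3 and bear on this change: a number 18 percentage points higher from compound 2 to compound 3 (beyond the scatter), and a number 16 percentage points higher from compound 1 to compound 3 (beyond the scatter). Both show that only the sulfinylmethyl group of compound 3 has so far lifted the read-out in this assay beyond the scatter, while the other two groups gave small numbers. Acetoxy is a group not yet seen here, so a drop back toward those lower numbers is expected, a number 10 percentage points lower from compound 3 to compound 4 (within the scatter). Compound 4 is therefore estimated at 8%, within a range from 0% to 25%.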

Compound 4, a percentage reported as inhibition, in the whole organism at one dose (the size of the read-out at that dose, not a potency): 87%
For compound 4 the middle estimate is 79 percentage points below the measured one; measured number outside the range, above it.
By their numbers in this assay, from the lowest: compounds 2 and 1 (each within the scatter of the next); then compound 3; then compound 4.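

On the saturated chain carbon bound to an aromatic carbon, the choice of group can change the result greatly: in this assay, acetoxy in place of the sulfinyl group gives a number 69 percentage points higher from compound 3 to compound 4 (beyond the scatter) and acetoxy in place of ethylsulfanyl gives a number 87 percentage points higher from compound 2 to compound 4 (beyond the scatter). Acetoxymethyl in place of carbamoyl on an aromatic carbon gives a number 85 percentage points higher from compound 1 to compound 4 (beyond the scatter), so the earlier, much smaller steps had not revealed how high this read-out could go. No measurement shown here explains the jump. On these data alone, whether a hydroxyl or a longer acyl chain on that same carbon would keep the effect remains open. A single dose also leaves potency unknown.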